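Swapping a benzimidazole for methoxyphenyl: a solubility estimate

The source may hold more compounds than are shown below. What is called first, only, known or untested is meant among the compounds shown, and "the series" means these compounds.

Measured compounds:
compound 1 `CNC(=O)c1cc(C(=O)NC2CCC2)cn(Cc2ccncc2)c1=O` gives 121 ug/mL
compound 2 `CNC(=O)c1cc(C(=O)NC2CCC2)cn(Cc2cccnc2)c1=O` gives 189 ug/mL
compound 3 `CNC(=O)c1cc(C(=O)NC2CC2)cn(Cc2ccc3nc[nH]c3c2)c1=O` gives 225 ug/mL

In a physicochemical assay for solubility, read by HPLC, in simulated intestinal fluid, with a stated time of 16 h, tested at 125 ug/mL (a lower number here means a less soluble compound, a higher number a more soluble compound), compound 3 gives the highest of the three numbers, yet its gaps to compound 2 and to compound 1 both lie within the scatter. Compound 4 `CNC(=O)c1cc(C(=O)NC2CC2)cn(Cc2ccc(OC)cc2)c1=O` differs from compound 3 in one place: 4-methoxyphenyl in place of 1H-benzimidazol-6-yl on a saturated chain carbon bound to an aromatic nitrogen. Among the measured compounds shown here, the only step measured between compounds, a 1.6-fold higher number from compound 1 to compound 2 (0.19 log units; within the scatter), exchanges one pyridyl for another and so does not speak to this change; no measured pair bears on it. The three numbers cluster closely, so no clear direction is expected and a step within the scatter is the likeliest outcome. Compound 4 is therefore estimated at 130 ug/mL, with a range of 55 ug/mL to 230 ug/mL, an expected step of a 1.7-fold lower number from compound 3 to compound 4 (0.24 log units; within the scatter).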

Compound 4, solubility: 263 ug/mL
The estimate for compound 4 lay 2.0-fold (0.31 log units) below the measured number, and the stated range ends below it.
By their numbers in this assay, from the lowest: compounds 1, 2, 3 and 4 (each within the scatter of the next, the first and the last beyond it).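

In this assay, 4-methoxyphenyl in place of 1H-benzimidazol-6-yl on a saturated chain carbon bound to an aromatic nitrogen gives a step within the scatter (a 1.2-fold higher number from compound 3 to compound 4 (0.07 log units; within the scatter)). This exchange removes the hydrogen-bond donor counted on 1H-benzimidazol-6-yl, yet the two compounds cannot be told apart in this read-out. Nothing available accounts for this result.

Still open, as far as these compounds go, is whether an amine or a carboxylic acid at this place would give a step beyond the scatter. Also open, from the compounds shown here alone, is whether the same exchange would read alike on the core of compound 1.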